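Notes on the step from compound 2 to compound 3

A few compounds are considered here, and "the series" means these few. Any claim that something is new, unique, unknown or untested is made for them only; others in the source may bear on it.

Compound 1 (`COc1cc(NC(C)CCCNC(=O)NN)c2ncccc2c1`) gives > 100000 nM in a functional assay on SW-620 cells (Homo sapiens) for inhibition, read by MTT assay, with a stated time of 4 days (a lower number here means a stronger inhibitor, a higher number a weaker inhibitor), which is a limit. Compound 2 (`COc1cc(NC(C)CCCNC(=O)NNC(=O)NCCCO)c2ncccc2c1`) gives > 100000 nM in this assay, also a limit. Among the measured compounds shown here, the only measured step, a step that the two limits leave unreadable from compound 1 to compound 2, has no readable size, and the limit of > 100000 nM in this assay, at which 2 of the 2 values shown sit, holds both compounds. Compound 3 (`COc1cc(NC(C)CCCNC(=O)Nc2ccc(Cl)c(C(F)(F)F)c2)c2ncccc2c1`) differs from compound 2 by 4-chloro-3-(trifluoromethyl)phenyl in place of ((3-hydroxypropyl)carbamoyl)amino on an amide-type nitrogen. With no size available from a step that the two limits leave unreadable from compound 1 to compound 2, the expectation rests on the structural change alone, and stronger inhibition in this assay is the only direction open. Compound 3 is estimated at 20000 nM, within 4000 nM to 100000 nM. The expected change is an at least 5.0-fold lower number from compound 2 to compound 3 (0.69 log units; beyond the scatter).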

Compound 3, half-maximal inhibitory concentration: 23000 nM
Compound 3: the middle estimate sits 1.2-fold (0.06 log units) below what was measured; low and high end bracket the measured number.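

Among the compounds shown here, on the amide-type nitrogen, 4-chloro-3-(trifluoromethyl)phenyl in place of ((3-hydroxypropyl)carbamoyl)amino gives the first number in this assay that clears the limit, with an at least 4.3-fold lower number from compound 2 to compound 3 (0.63 log units; beyond the scatter). In place of amino on that nitrogen, the same group gives an at least 4.3-fold lower number from compound 1 to compound 3 (0.63 log units; beyond the scatter). The step from compound 1 to compound 2 cannot be read, and the two new steps are bounds only, set by the limit: the limit of > 100000 nM in this assay, at which 2 of the 3 values shown sit.

On these data alone, the true size of both steps stays open. Also open, as far as these compounds go, is whether the chlorine, the trifluoromethyl or the phenyl ring carries the change, and what a plain phenyl or a longer alkyl chain on that nitrogen would give.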